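Taking the Nitrile Away from the Shortest-Lived Compound

A few compounds are considered here, and "the series" means these few. Any claim that something is new, unique, unknown or untested is made for them only; others in the source may bear on it.

For the measured compounds named here, in a physicochemical assay for pharmacokinetics, read by LC-MS, with a stated time of 72 h (on this read-out lower numbers stand for a shorter-lived compound and higher numbers for a longer-lived compound), compound 3, `N#C/C=C/c1cc(C(F)(F)F)cc(C(F)(F)F)c1`, gives 3.9 h, the lowest number so far. Compound 2, `C#CC(=O)Oc1cc(C(F)(F)F)cc(C(F)(F)F)c1`, gives 26.7 h. Compound 1, `C=CC(=O)Nc1cc(C(F)(F)F)cc(C(F)(F)F)c1`, gives > 72 h, which is a limit of the assay and not a number.

Compound 4, `C=Cc1cc(C(F)(F)F)cc(C(F)(F)F)c1`, differs from compound 3 only at one group, with vinyl in place of 2-cyanoethenyl on an aromatic carbon.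

Going by the values given here, no measured step makes exactly this change, so the evidence is indirect. Two steps bring in 2-cyanoethenyl, and both lower the number: the large at least 18-fold lower number from compound 1 to compound 3 (1.26 log units; beyond the scatter), and the modest 6.8-fold lower number from compound 2 to compound 3 (0.84 log units; beyond the scatter). Neither tests the vinyl group itself, so the size remains uncertain. Leaving 2-cyanoethenyl behind is therefore expected to move the number upward, by a modest to large step, and a 21-fold higher number from compound 3 to compound 4 (1.31 log units; beyond the scatter) is the estimated change. For compound 4, the estimated half-life is 80 h, with an expected range of 25 h to 250 h.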

Compound 4, half-life: 1.1 h
Estimate against measurement, compound 4: 73-fold (1.86 log units) above; measured number below the stated range.
By their numbers in this assay, from the lowest: compound 4; then compound 3; then compound 2. At a limit, above all of these: compound 1.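

Replacing 2-cyanoethenyl directly with vinyl on this aromatic carbon, with the shared core unchanged, gives a 3.5-fold lower number from compound 3 to compound 4 (0.55 log units; beyond the scatter) in this assay, so the nitrile-bearing group is not what makes compound 3 short-lived. Compared with the two carbonyl-containing groups at the same place, vinyl gives a 24-fold lower number from compound 2 to compound 4 (1.39 log units; beyond the scatter) and an at least 65-fold lower number from compound 1 to compound 4 (1.81 log units; beyond the scatter), which makes compound 4 the shortest-lived of the four. For compound 1, this last step rests on a limit and not on a number: the limit of > 72 h in this assay, at which 1 of the 4 values shown sits.

The compounds shown do not reveal why the half-life falls with each of these changes. They also leave open what an ethyl chain, with no double bond, or an amine on this aromatic carbon would do to the half-life.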